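The source may report more compounds than this note shows. Statements on the series, on what has been measured and on what is new or still open speak of the compounds shown alone.

Compound 1 `C[C@@H](O)[C@H]1C(=O)N2C(C(=O)OCOC(=O)OC3CCCCC3)=C(S[C@@H]3CN[C@H](C(=O)Nc4cccc(C(=O)O)c4)C3)[C@H](C)[C@H]12` sits at the bottom of the three numbers gathered so far: in an ADME assay on a cell-free system (plasma, Rattus norvegicus) for metabolic stability, read by LC-MS, with a stated time of 60 min, at 37 degrees C, tested at 50 uM (a lower number here means that less of the compound is left, a higher number that more of the compound is left), compound 1 gives 0%, and compound 2 `CCOC(=O)C1=C(S[C@@H]2CN[C@H](C(=O)Nc3cccc(C(=O)OCC)c3)C2)[C@H](C)[C@@H]2[C@@H]([C@@H](C)OC(=O)[C@@H](N)C(C)C)C(=O)N12` gives 0%, no change at the digits shown. Compound 3 `C[C@@H](O)[C@H]1C(=O)N2C(C(=O)OCOC(=O)OC3CCCCC3)=C(S[C@@H]3CN[C@H](C(=O)Nc4cccc(C(=O)OCOC(=O)OC5CCCCC5)c4)C3)[C@H](C)[C@H]12` gives 10%, and the step of a number 10 percentage points higher from compound 1 to compound 3 (within the scatter) stays within the scatter. Compound 4 `COC(=O)OCOC(=O)C1=C(S[C@@H]2CN[C@H](C(=O)Nc3cccc(C(=O)O)c3)C2)[C@H](C)[C@@H]2[C@@H]([C@@H](C)O)C(=O)N12` is compound 1 with methyl in place of cyclohexyl on an oxygen next to a carbonyl group. Going by the values given here, no measured step shares this change; the only step in the set, from compound 1 to compound 3, moves the other ester and was within the scatter, so nothing here points to a shift beyond the scatter. The expected step of a number 3 percentage points higher from compound 1 to compound 4 (within the scatter) is therefore small. For compound 4 an estimate of 3% is expected, in the range 0% to 15%.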

Compound 4, percent of the compound remaining: 0%
Estimate against measurement, compound 4: 3 percentage points above; the measured number falls inside the stated range.
By their numbers in this assay, from the lowest: compounds 1, 2, 4 and 3 (each within the scatter of the next).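

Going by these compounds alone, this is the first step read at this position: with methyl in place of cyclohexyl on an oxygen next to a carbonyl group, this assay gives no change at the digits printed from compound 1 to compound 4 (within the scatter). Removing the six-membered carbon ring, and going from 6 heavy atoms to 1, therefore leaves the read-out within the scatter, with both compounds among the lowest numbers in the set. No measurement available here bears on the reason for this result.

From the compounds shown here alone, whether a longer chain such as butyl, or a chain ending in an amine, on this oxygen would move the number beyond the scatter from compound 1 remains open.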